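Switching the acyl group on the shared core

The source may hold more compounds than are shown below. What is called first, only, known or untested is meant among the compounds shown, and "the series" means these compounds.

Compound 2 `CN(C(=O)NC(=O)c1cccc(C(F)(F)F)c1)c1nc(C(F)(F)F)c(C(=O)N/N=C/c2ccccc2C(F)(F)F)s1`: 7.29 ug/mL
Compound 1 `CN(C(=O)NC(=O)c1cccc(C(F)(F)F)c1)c1nc(C(F)(F)F)c(C(=O)N/N=C/c2ccc(C(F)(F)F)cc2)s1`: 4.22 ug/mL

Compound 2 gives the higher of the two numbers in a functional assay on BCG823 cells (Homo sapiens) for inhibition, read by MTT assay, with a stated time of 72 h (a lower number here means a stronger inhibitor, a higher number a weaker inhibitor), and compound 1 is within the scatter of it, since a 1.7-fold higher number from compound 1 to compound 2 (0.24 log units; within the scatter). That single step alters the aryl on the carbon with a double bond to nitrogen and does not touch the carbonyl side. Compound 3 `CN(C(=O)NC(=O)c1c(Cl)cccc1Cl)c1nc(C(F)(F)F)c(C(=O)N/N=C/c2ccccc2C(F)(F)F)s1` instead carries 2,6-dichlorophenyl in place of 3-(trifluoromethyl)phenyl on a carbonyl carbon. Within the data shown here, no measured step bears on this change, so the estimate leans on compound 2 with a wide range. Compound 3 is expected at 7 ug/mL (range 2.5 ug/mL to 20 ug/mL), a step of a 1.0-fold lower number from compound 2 to compound 3 (0.02 log units; within the scatter).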

Compound 3, half-maximal inhibitory concentration: 4.12 ug/mL
Compound 3: middle estimate off by 1.7-fold (0.23 log units), on the high side; measured number inside the range.
By their numbers in this assay, from the lowest: compounds 3, 1 and 2 (each within the scatter of the next).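

At this position, the carbonyl carbon whose other neighbour is an amide-type nitrogen, the swap of 3-(trifluoromethyl)phenyl for 2,6-dichlorophenyl gives a 1.8-fold lower number from compound 2 to compound 3 (0.25 log units; within the scatter) in this assay. The two aryl groups therefore read alike here, so this carbonyl side, like the aryl on the carbon with a double bond to nitrogen, has so far shown no step beyond the scatter. Nothing available here offers an explanation for this result. As far as these compounds go, it remains open whether an aryl group is needed on this carbonyl carbon at all, or whether an amine or a longer alkyl chain would read differently. Also open, from the compounds shown here alone, is whether 2,6-dichlorophenyl behaves the same alongside the 4-(trifluoromethyl)phenyl of compound 1.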